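Taking the isopropyl group off compound 2

This account rests on a few compounds, and the source may have more. Where it says the series, first, only, none or still open, it means among the compounds named here.

In a physicochemical assay for permeability, using PAMPA (a lower number here means that the compound crosses the layer more slowly, a higher number that the compound crosses the layer faster), compound 1 `Cc1ccccc1-c1nc(CN2CCC(C(=O)NCCCN3CC(C)(C)CC(C)(C)C3)CC2)c(C)o1` reports only a limit, > 1390 10^-6 cm/s. Going by the values given here, compound 2 `Cc1ccccc1-c1nc(CN2CCC(C(=O)NCCCN3CCC(C(C)C)CC3)CC2)c(C)o1` gives 396 10^-6 cm/s, the only exact number so far in this assay. Compound 3 `Cc1ccccc1-c1nc(CN2CCC(C(=O)NCCCN3CCCCC3)CC2)c(C)o1` has hydrogen in place of isopropyl on a saturated ring carbon. Among the compounds with values here, one measured step bears on this, though it is a different change: an at least 3.5-fold lower number from compound 1 to compound 2 (0.54 log units; beyond the scatter), at least modest and beyond the scatter, in which a smaller group came with a lower number. A further fall of similar size is therefore expected, an estimated 2.3-fold lower number from compound 2 to compound 3 (0.37 log units; beyond the scatter). For compound 3 the expected value is 170 10^-6 cm/s, with an estimated range of 60 10^-6 cm/s to 450 10^-6 cm/s.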

Compound 3, apparent permeability: 34.5 10^-6 cm/s
Compound 3: middle estimate off by 4.9-fold (0.69 log units), on the high side; the measured number lies below the stated range.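

In this assay, going by these compounds alone, hydrogen in place of isopropyl on this saturated ring carbon, three ring bonds from the ring nitrogen, gives an 11-fold lower number from compound 2 to compound 3 (1.06 log units; beyond the scatter), the first step here with exact values at both ends. The wider step, an at least 40-fold lower number from compound 1 to compound 3 (1.60 log units; beyond the scatter), is only a floor, as its starting value is a limit: the limit of > 1390 10^-6 cm/s in this assay, at which 1 of the 3 values shown sits.

As far as these compounds go, what a methyl, a hydroxyl or an amine on this ring carbon would give stays open. The compounds shown therefore cannot say whether the number falls evenly with the size of the group or sharply at one point.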